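Methoxy for methyl on the triazole aryl arm

This account rests on a few compounds, and the source may have more. Where it says the series, first, only, none or still open, it means among the compounds named here.

Compound 1 `C=C1C[C@]23C[C@@]1(O)CC[C@H]2c1ccc(OS(=O)(=O)c2ccc(C)cc2)c(C)c1[C@@H]3Cn1cc(-c2ccc(OC)cc2)nn1` and compound 2 `C=C1C[C@]23C[C@@]1(O)CC[C@H]2c1ccc(OS(=O)(=O)c2ccc(C)cc2)c(C)c1[C@@H]3Cn1cc(-c2ccc(C)cc2)nn1` share a tosylated core that carries a methylene at the cyclohexanol ring, and both carry a triazole bearing an aryl group. In a functional assay on MCF7 cells (Homo sapiens) for cytotoxicity, read by MTT assay, with a stated time of 4 days (a lower number here means a stronger inhibitor, a higher number a weaker inhibitor), compound 1 gives only a limit, > 20000 nM. In this assay compound 2 likewise gives only a limit, > 20000 nM. The change from compound 2 to compound 1 is methoxy in place of methyl on an aromatic carbon, and its step reads a step that the two limits leave unreadable from compound 2 to compound 1; both ends sit at the limit of > 20000 nM in this assay, at which 2 of the 3 values shown sit, so the size of that step is not readable.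

Compound 3 `C=C1C(=O)[C@]23C[C@@]1(O)CC[C@H]2c1ccc(O)c(C)c1[C@@H]3Cn1cc(-c2ccc(C)cc2)nn1` has a different core, with a free phenol and a carbonyl in place of the tosylate and methylene; the difference between its core and the core of compound 2 is not broken down here. In this assay, among the measured compounds shown here, compound 3 gives 370 nM, the only numerical value in the set.

Compound 4 `C=C1C(=O)[C@]23C[C@@]1(O)CC[C@H]2c1ccc(O)c(C)c1[C@@H]3Cn1cc(-c2ccc(OC)cc2)nn1` is the counterpart of compound 3 with the change (methoxy in place of methyl on an aromatic carbon), the same change as from compound 2 to compound 1, at the same kind of place. Since the earlier step is unreadable, the expectation for compound 4 rests only on the reading of compound 3 and on the assumption that the aryl substituent matters little: the step from compound 3 to compound 4 is expected to be a 1.2-fold higher number from compound 3 to compound 4 (0.09 log units; within the scatter), within the usual scatter. Compound 4 is therefore estimated at 450 nM, with a range from 150 nM to 1500 nM.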

Compound 4, half-maximal inhibitory concentration: 1710 nM
For compound 4 the middle estimate is 3.8-fold (0.58 log units) below the measured one, and the stated range ends below it.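

In this assay, the change from 4-methylphenyl to 4-methoxyphenyl on the core of compound 3 gives a 4.6-fold higher number from compound 3 to compound 4 (0.66 log units; beyond the scatter), so on this core the methoxy arm reads as the weaker of the two. The same change on the tosylated core cannot be read, since compound 1 and compound 2 each stand only at a limit of the assay: the limit of > 20000 nM in this assay, at which 2 of the 4 values shown sit. The series therefore gives a size for this change on one core only, and it does not show whether that size, or even its direction, carries over to the other core.

The compounds shown leave open whether the step on the core of compound 3 is particular to methoxy or extends to other groups on the aryl arm in place of the methyl, such as an amine, a carboxylic acid or a longer chain. Also open is which of the differences between the two cores, the free phenol against the tosylate or the carbonyl present only in the core of compound 3, separates the measurable compounds from those at the limit, as no pair shown changes just one of them.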